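The source may report more compounds than this note shows. Statements on the series, on what has been measured and on what is new or still open speak of the compounds shown alone.

Compound 1 `C[C@H](NC(=O)Cn1nnc2ccccc2c1=O)c1ccc(Br)cc1`, an ADME assay on microsomes from liver (Homo sapiens) for metabolic stability; on this read-out lower numbers stand for slow clearance and higher numbers for fast clearance: < 9.9 mL/min/kg
Compound 2 `Cc1ccc([C@H](C)NC(=O)Cn2nnc3ccccc3c2=O)nc1`, this assay: < 9.9 mL/min/kg

Compound 2 reads < 9.9 mL/min/kg in this assay, and this is a limit, not a number. Both measured compounds sit on the same mark, (the limit of < 9.9 mL/min/kg in this assay, at which 2 of the 2 values shown sit). Among the measured compounds shown here, the one measured change at this place is a step that the two limits leave unreadable from compound 1 to compound 2, so it offers no size to carry forward.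

Compound 3 `Cc1ccc([C@H](C)NC(=O)Cn2nnc3ccccc3c2=O)cn1` keeps the shared core and the chain. Only the ring group differs: 6-methylpyridin-3-yl stands in place of 5-methylpyridin-2-yl on a saturated chain carbon bound to an amide-type nitrogen and a saturated chain carbon (6-methylpyridin-3-yl in place of 5-methylpyridin-2-yl on a saturated chain carbon bound to an amide-type nitrogen and a saturated chain carbon). With no readable step to guide it, no step beyond the scatter is expected in this assay, and no direction can be given. The expected change is a step that the limit leaves unreadable from compound 2 to compound 3. Compound 3 is estimated at 9 mL/min/kg, with an expected range from 5 mL/min/kg to 16 mL/min/kg.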

Compound 3, clearance in the Homo sapiens assay: < 9.9 mL/min/kg
Compound 3: no number, only a limit; the forecaster's own chance of this, stated with the estimate: 65%; the middle value does not contradict the limit.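

In the Homo sapiens assay compound 3 gives < 9.9 mL/min/kg, which is a limit and not a number. No step among compound 1, compound 2 and compound 3 can be read, since all three stand on one mark: the limit of < 9.9 mL/min/kg in the Homo sapiens assay, at which 3 of the 3 values shown sit.

The compounds shown leave open how large the clearance of each one really is, and whether their ring groups separate them on this read-out at all.

In a physicochemical assay for solubility, read by HPLC, in phosphate buffer, with a stated time of 16 h, at pH 6.8 (on this read-out lower numbers stand for lower solubility and higher numbers for higher solubility), compound 2 gives 2000 nM and compound 3 gives 9800 nM. With 6-methylpyridin-3-yl in place of 5-methylpyridin-2-yl, the physicochemical assay shows a 4.9-fold higher number from compound 2 to compound 3 (0.69 log units; beyond the scatter).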